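The source may report more compounds than this note shows. Statements on the series, on what has been measured and on what is new or still open speak of the compounds shown alone.

Measured compounds in the series:

- compound 2, `CC(C)(C)c1ccc(SCc2ccc(/C=C/C(=O)Nc3ccccc3N)cc2)cc1`: 640 nM
- compound 3, `COc1ccc(SCc2ccc(C(=O)Nc3ccccc3N)cc2)cc1OC`: 5680 nM
- compound 1, `Nc1ccccc1NC(=O)c1ccc(CSc2cccc(F)c2)cc1`: "not determined" (no result reported)

In a functional assay on A549 cells (Homo sapiens) for antiproliferative activity, read by CCK-8 assay, with a stated time of 72 h (on this read-out higher numbers stand for weaker inhibition and lower numbers for stronger inhibition), compound 2 gives 640 nM, the lower of the two numbers in hand. Compound 3 gives 5680 nM, a gap that lies beyond the scatter of repeated runs. Compound 1 carries no number and cannot be placed. For the measured compounds named here, no pair of measured compounds differs in a single place, so no measured step is available to lean on.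

Compound 4, `CCc1ccc(SCc2ccc(/C=C/C(=O)Nc3ccccc3N)cc2)cc1`, differs from compound 2 in one place: ethyl in place of tert-butyl on an aromatic carbon. Nothing in the measured set isolates this change, so the expectation rests on the closeness of the two structures alone. In this assay no step beyond the scatter is expected in either direction. Compound 4 is estimated at 850 nM, with a range from 300 nM to 2500 nM. The implied step from compound 2 is expected to be a 1.3-fold higher number from compound 2 to compound 4 (0.12 log units; within the scatter), a difference that would not be distinguishable from repeat-to-repeat variation.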

Compound 4, half-maximal inhibitory concentration: 1300 nM
The estimate for compound 4 lay 1.5-fold (0.18 log units) below the measured number; low and high end bracket the measured number.
By their numbers in this assay, from the lowest: compound 2; then compound 4; then compound 3.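

In this assay, for the compounds shown here, the change from 4-(tert-butyl)phenyl to 4-ethylphenyl provides the first measured step at a single place: a 2.0-fold higher number from compound 2 to compound 4 (0.31 log units; beyond the scatter). This position, on an aromatic carbon para to a large group, therefore responds to the group it carries, although the modest step lies only just beyond the scatter, and the larger tert-butyl, with 4 heavy atoms against 2 for ethyl, sits on the lower number of this pair. No measurement in hand accounts for the step.

Going by these compounds alone, with only two groups compared at this place, a single step sets no trend, and the effect of a hydrogen, a trifluoromethyl, an amine or a carboxylic acid there remains open. As far as these compounds go, whether the same exchange gives a similar step on the core of compound 3 also remains open.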